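A Nitro Group Added to a Weakly Cytotoxic Core

The source may report more compounds than this note shows. Statements on the series, on what has been measured and on what is new or still open speak of the compounds shown alone.

Compound 1 `Clc1ccc(Cc2nn3cc(-c4ccccc4)nc3s2)cc1` was tested in a functional assay on L1210 cells (Mus musculus) for cytotoxicity, with a stated time of 48 h; a higher number here means a weaker inhibitor, a lower number a stronger inhibitor. Compound 1 reaches only the limit of the assay, giving > 250000 nM. Compound 2 `O=[N+]([O-])c1ccc(-c2cn3nc(Cc4ccc(Cl)cc4)sc3n2)cc1` differs from compound 1 by nitro in place of hydrogen on an aromatic carbon. In this assay compound 2 gives 214000 nM, a step of an at least 1.1-fold lower number from compound 1 to compound 2 (0.06 log units; that floor lies within the scatter). Compound 3 `Clc1ccc(Cc2nn3c(Br)c(-c4ccccc4)nc3s2)cc1` differs from compound 1 by bromo in place of hydrogen on an aromatic carbon. Compound 3 also reaches only a limit in this assay, namely > 250000 nM. The step that the two limits leave unreadable from compound 1 to compound 3 cannot be sized because of the limit of > 250000 nM in this assay, at which 2 of the 3 values shown sit. Compound 4 `O=[N+]([O-])c1ccc(-c2nc3sc(Cc4ccc(Cl)cc4)nn3c2Br)cc1` differs from compound 3 by nitro in place of hydrogen on an aromatic carbon, the same change as that from compound 1 to compound 2, the two places being described alike. Compound 4 is expected to give about 240000 nM in this assay, quite possibly only as a limit. That estimate means an expected step of an at least 1.0-fold lower number from compound 3 to compound 4 (0.01 log units; that floor lies within the scatter), and it rests on the small step of an at least 1.1-fold lower number from compound 1 to compound 2 (0.06 log units; that floor lies within the scatter).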

Compound 4, half-maximal inhibitory concentration: 94000 nM
Compound 4: the middle estimate sits 2.6-fold (0.41 log units) above what was measured; the whole stated range lies above it.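

In this assay nitro in place of hydrogen on the bromo-bearing core gives an at least 2.6-fold lower number from compound 3 to compound 4 (0.42 log units; beyond the scatter), and bromo in place of hydrogen with the nitro group present gives a 2.3-fold lower number from compound 2 to compound 4 (0.36 log units; beyond the scatter). The number thus falls on both cores when the nitro group enters, but this does not show that the step keeps its size from one core to the other: the same change on two cores in this assay, an at least 1.1-fold lower number (0.06 log units; that floor lies within the scatter) from compound 1 to compound 2 and an at least 2.6-fold lower number (0.42 log units; beyond the scatter) from compound 3 to compound 4; the limit leaves it open whether they differ. On these data alone, the size of the nitro step on the core of compound 1 stays unknown, since compound 1 gives only a limit, and no firm comparison follows: the limit of > 250000 nM in this assay, at which 2 of the 4 values shown sit.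

The compounds shown leave open whether an amine or a carboxylic acid at the same place on the six-membered ring would give a step like that of nitro. They also leave open whether such a step would differ between the two cores.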